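A few compounds are considered here, and "the series" means these few. Any claim that something is new, unique, unknown or untested is made for them only; others in the source may bear on it.

Measured in a functional assay on HCT-116 cells (Homo sapiens) for antiproliferative activity, read by sulforhodamine B assay, with a stated time of 72 h (on this read-out higher numbers stand for weaker inhibition and lower numbers for stronger inhibition), so far:
compound 1 `Cn1ncc(Cl)c1-c1cc(C(=O)N[C@@H]2CN[C@H](CCn3cncn3)C[C@H]2c2ccc(Cl)c(Cl)c2)oc1Cl` gives 560 nM
compound 2 `CC(=O)NCC[C@@H]1C[C@@H](c2ccc(F)c(F)c2)[C@H](NC(=O)c2cc(-c3c(Cl)cnn3C)c(Cl)o2)CN1` gives 920 nM

These two numbers lie within the usual scatter of repeated measurements, so compound 1 stands level with compound 2 and neither can be ranked over the other.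

Compound 3 `Cn1ncc(Cl)c1-c1cc(C(=O)N[C@@H]2CN[C@H](CC(=O)NC3CC3)C[C@H]2c2ccc(Cl)c(Cl)c2)oc1Cl` has not yet been measured. It keeps the core of compound 1 and differs in one place, where cyclopropylcarbamoyl stands in place of (1H-1,2,4-triazol-1-yl)methyl on a saturated chain carbon bound to a saturated ring carbon. The counted difference is cyclopropylcarbamoyl in place of (1H-1,2,4-triazol-1-yl)methyl on a saturated chain carbon bound to a saturated ring carbon and nothing else in the structure changes.

Among the measured compounds shown here, no measured pair shows this change on its own, as compound 2 differs from compound 1 in more than one place. Even so, compound 2 gives 920 nM in spite of those differences, so a large shift is not expected. The estimated step of a 1.2-fold higher number from compound 1 to compound 3 (0.06 log units; within the scatter) is expected to stay within the scatter, with no clear direction. In this assay compound 3 is estimated at 650 nM with an expected range from 220 nM to 1900 nM for the measurement.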

Compound 3, half-maximal inhibitory concentration: 740 nM
The estimate for compound 3 lay 1.1-fold (0.06 log units) below the measured number, and the stated range covers the measured number.
By their numbers in this assay, from the lowest: compounds 1, 3 and 2 (each within the scatter of the next).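

In this assay, among the compounds shown here, this is the first direct reading of a single change at this position: with the core of compound 1 held fixed, cyclopropylcarbamoyl in place of (1H-1,2,4-triazol-1-yl)methyl gives a 1.3-fold higher number from compound 1 to compound 3 (0.12 log units; within the scatter) and leaves the two compounds level. The exchange is a real change of structure even though the heavy-atom count stays the same, since a five-membered aromatic ring with 3 hetero atoms leaves, while a three-membered carbon ring, a double bond outside aromatic rings and a hydrogen-bond donor enter, yet this read-out does not separate the two groups. Nothing measured here explains why these two different groups stand level.

As far as these compounds go, these two groups alone cannot show how much freedom this position allows, so it remains open whether a carboxylic acid, a primary amine or a longer plain carbon chain on this saturated chain carbon would also stay level with compound 1. From the compounds shown here alone, it also remains open whether the same exchange would give the same small step on a different core.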